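A few compounds are considered here, and "the series" means these few. Any claim that something is new, unique, unknown or untested is made for them only; others in the source may bear on it.

Working notes on the series. Among the compounds with values here, compound 2 `CCNc1nc(NCc2ccc(C(=O)Nc3ccc(F)cc3)cc2)c2ccccc2n1` is the weaker of the two measured entries in a functional assay on SW480 cells (Homo sapiens) for inhibition, read by luminescence and resazurin assay, with a stated time of 3 days (a higher number here means a weaker inhibitor, a lower number a stronger inhibitor), where compound 2 gives 2500 nM; its nearest neighbour is compound 1 `CCNc1nc(NCc2ccc(NC(=O)c3ccc(F)cc3)cc2)c2ccccc2n1`, for which compound 1 gives 2300 nM, and the single step on record, a 1.1-fold higher number from compound 1 to compound 2 (0.04 log units; within the scatter), lies within the scatter, so neither can be called weaker or stronger. Compound 3 `C=CCNc1nc(NCc2ccc(C(=O)Nc3ccc(F)cc3)cc2)c2ccccc2n1` is the next entry; the change is vinyl in place of methyl on a saturated chain carbon bound to a nitrogen on an aromatic ring. Within the data shown here, no measured step touches this part of the molecule: the one step on record, a 1.1-fold higher number from compound 1 to compound 2 (0.04 log units; within the scatter), concerns the amide arrangement on the other side of the core and says nothing about the chain on the aromatic nitrogen. With nothing to point either way, the step of no change at the digits printed from compound 2 to compound 3 (within the scatter) in this assay is expected to stay within the scatter. Compound 3 is therefore estimated at 2500 nM, in the range 1200 nM to 5200 nM.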

Compound 3, half-maximal inhibitory concentration: 11000 nM
Estimate against measurement, compound 3: 4.4-fold (0.64 log units) below; the measured number lies above the stated range.
By their numbers in this assay, from the lowest: compounds 1 and 2 (each within the scatter of the next); then compound 3.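

Within the data shown here, the chain on the aromatic nitrogen is the first place where a change registers in this assay: ethyl to allyl gives a 4.4-fold higher number from compound 2 to compound 3 (0.64 log units; beyond the scatter) while the only earlier step, the swapped amide arrangement, stayed within the scatter. This position is therefore sensitive to at least one small change, since a single added carbon and a double bond outside aromatic rings are enough for a modest loss of inhibition. Nothing available explains this loss.

The compounds shown leave open whether the added carbon or the double bond accounts for the step, a question that a propyl chain on this nitrogen would address. They also leave open how a methyl, a longer alkyl chain or a terminal amine on the same nitrogen would read.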